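Does an isopropyl group help compound 3?

This account rests on a few compounds, and the source may have more. Where it says the series, first, only, none or still open, it means among the compounds named here.

Measured in a functional assay on KG-1 cells (Homo sapiens) for antiproliferative activity, read by CCK-8 assay, with a stated time of 72 h; a lower number here means a stronger inhibitor, a higher number a weaker inhibitor:
- compound 1 `Cc1ccc(C(=O)Nc2cccc(C(F)(F)F)c2)cc1-c1ccc2c(-c3ccc(N4CCN(C)CC4)cc3)n[nH]c2c1`: 136 nM
- compound 2 `Cc1ccc(C(=O)Nc2cccc(C(F)(F)F)c2)cc1-c1ccc2c(-c3ccc(CN4CCN(C)CC4)cc3)n[nH]c2c1`: 120 nM
- compound 3 `Cc1ccc(C(=O)Nc2cccc(C(F)(F)F)c2)cc1-c1ccc2c(-c3cn[nH]c3)n[nH]c2c1`: > 1000 nM (a limit, not a number)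

Compound 3 sits at the limit of > 1000 nM in this assay, at which 1 of the 3 values shown sits. Compound 4 `Cc1ccc(C(=O)Nc2cccc(C(F)(F)F)c2)cc1-c1ccc2c(-c3cnn(C(C)C)c3)n[nH]c2c1` carries isopropyl in place of hydrogen on an aromatic nitrogen.

Among the measured compounds shown here, the only measured step, a 1.1-fold lower number from compound 1 to compound 2 (0.05 log units; within the scatter), lies within the scatter. It concerns a different change, (4-methylpiperazin-1-yl)methyl in place of 4-methylpiperazin-1-yl, so it gives no direct guide to the size of this one. The better clue is compound 1, which reaches 136 nM in this assay with a larger group in place of 1H-pyrazol-4-yl. Compound 2 likewise reaches 120 nM. A modest gain is therefore expected, with considerable uncertainty and a real chance of another limit. The expected change, towards a lower number, is an at least 2.0-fold lower number from compound 3 to compound 4 (0.30 log units; that floor lies within the scatter). Compound 4 is estimated at 500 nM, with an expected range of 100 nM to 2000 nM.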

Compound 4, half-maximal inhibitory concentration: 452 nM
Compound 4: middle estimate off by 1.1-fold (0.04 log units), on the high side, and the stated range covers the measured number.
By their numbers in this assay, from the lowest: compounds 2 and 1 (each within the scatter of the next); then compound 4. At a limit, above all of these: compound 3.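

In this assay compound 3 has > 1000 nM as a limit and not as a number. Putting isopropyl on the aromatic nitrogen of the 1H-pyrazol-4-yl group gives an at least 2.2-fold lower number from compound 3 to compound 4 (0.34 log units; beyond the scatter) and so shows that this nitrogen can carry a small carbon group, with a change beyond the scatter. The true size of the step stays unknown because only a floor can be read from it: the limit of > 1000 nM in this assay, at which 1 of the 4 values shown sits.

Among the compounds shown here, only one group on this nitrogen appears here, so it remains open whether a methyl group, a longer carbon chain or a chain ending in an amine would lower the number further. The compounds shown also leave open why isopropyl lowers the number in this assay and whether the gain comes from its size or from something else.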